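Chloro in place of hydrogen: outlook for compound 3

The compounds below may be only part of what the source reports. "The series", "measured", "known", "first", "only" and "open" are said of these compounds alone.

Measured compounds:
compound 1, `COCCN/C(=C1/N=CN(CCOC)C1=O)c1cc2ccccc2[nH]1`: 460 nM
compound 2, `COCCCN/C(=C1/N=CN(CCOC)C1=O)c1cc2ccccc2[nH]1`: 1020 nM

Within the data shown here, in an assay on isolated protein for inhibition of Calpain-1 catalytic subunit (Homo sapiens), read by fluorescence, with a stated time of 60 min (on this read-out higher numbers stand for weaker inhibition and lower numbers for stronger inhibition), compound 1 gives 460 nM, the lowest of the two numbers so far. Among the measured compounds shown here, compound 2 gives 1020 nM; the single step, a 2.2-fold higher number from compound 1 to compound 2 (0.35 log units; beyond the scatter), follows a change on the chain two bonds from the amine nitrogen.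

Compound 3, `COCCN/C(=C1/N=CN(CCOC)C1=O)c1[nH]c2ccccc2c1Cl`, differs from compound 1 by chloro in place of hydrogen on an aromatic carbon. For the measured compounds named here, no measured step touches the aromatic part of the shared core; the step from compound 1 to compound 2 concerns a saturated chain and does not bear on this change. The series therefore gives no direction for the effect of the chloro group.

With nothing to point either way, compound 3 is expected to stay near compound 1, a step of a 1.2-fold lower number from compound 1 to compound 3 (0.06 log units; within the scatter) within the scatter. The estimate for compound 3 is 400 nM, with a range from 130 nM to 1200 nM.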

Compound 3, half-maximal inhibitory concentration: > 1000 nM
Compound 3 was reported as a limit (the forecaster's own chance of this, stated with the estimate: 5%); middle value at least 2.5-fold (0.39 log units) away from the limit.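

In this assay compound 3 gives > 1000 nM, which is a limit and not a number. Chloro in place of hydrogen, on an aromatic carbon of the five-membered aromatic ring with 1 nitrogen, gives an at least 2.1-fold higher number from compound 1 to compound 3 (0.33 log units; beyond the scatter), so the series does not keep its number at this position when this group enters. Among these compounds, this is the first measured step on the aromatic part of the shared core, and it shows that the read-out responds to a change there, not only to a change on the saturated chain.

As far as these compounds go, the size of the step remains open beyond its printed bound. Also open, from the compounds shown here alone, is whether fluoro, methyl or a hydroxyl group at this same carbon would give a step in the same direction as chloro.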